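Swapping One Side Group on the Shared Core

A few compounds are considered here, and "the series" means these few. Any claim that something is new, unique, unknown or untested is made for them only; others in the source may bear on it.

Compound 2 `COc1ccc(CN(C(=O)Cn2cc(CSC3=NCCS3)nn2)c2cc(OC)c(OC)c(OC)c2)cc1` is tested in a functional assay on PC-3 cells (Homo sapiens) for antiproliferative activity, read by MTT assay, with a stated time of 48 h (on this read-out lower numbers stand for stronger inhibition and higher numbers for weaker inhibition), and gives 16000 nM in that test, within the scatter of compound 3 `COc1ccc(CN(C(=O)Cn2cc(CSc3nnc(-c4ccccc4)c(-c4ccccc4)n3)nn2)c2cc(OC)c(OC)c(OC)c2)cc1` at 19600 nM and far higher than compound 1 `COc1ccc(CN(C(=O)Cn2cc(COc3ccc4c(C)cc(=O)oc4c3)nn2)c2cc(OC)c(OC)c(OC)c2)cc1` at 340 nM on the same scale. Compound 4 `COc1ccc(CN(C(=O)Cn2cc(CNS(=O)(=O)c3ccc(C)cc3)nn2)c2cc(OC)c(OC)c(OC)c2)cc1` carries one change from compound 2, namely a group of 11 heavy atoms (7 carbon, 1 nitrogen, 2 oxygen, 1 sulfur; one six-membered aromatic ring of carbon only) in place of a group of 6 heavy atoms (3 carbon, 1 nitrogen, 2 sulfur; one five-membered non-aromatic ring with 2 hetero atoms), on a saturated chain carbon bound to an aromatic carbon with the rest of the molecule the same. For the measured compounds named here, no measured pair isolates this swap, and compound 1 at 340 nM keeps a much lower number possible, so only a small downward drift in this assay is expected, none beyond the scatter. The expected move is a 1.6-fold lower number from compound 2 to compound 4 (0.20 log units; within the scatter) in this estimate. Compound 4 is estimated at 10000 nM with 2500 nM to 30000 nM as its likely range.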

Compound 4, half-maximal inhibitory concentration: 12400 nM
Compound 4: middle estimate off by 1.2-fold (0.09 log units), on the low side, within the range that was stated.
By their numbers in this assay, from the lowest: compound 1; then compounds 4, 2 and 3 (each within the scatter of the next).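

In this assay, replacing the five-membered non-aromatic ring group with ((4-methylphenyl)sulfonyl)amino on this saturated chain carbon gives a 1.3-fold lower number from compound 2 to compound 4 (0.11 log units; within the scatter). This first direct step at the position shows that a larger group carrying a six-membered aromatic ring of carbon only and a hydrogen-bond donor leaves the number within the scatter. Nothing available explains this result. Left open is whether a simple amine or a carboxylic acid at this place would also stay within the scatter. Also open, on these data alone, is what sets compound 1, at 340 nM, apart.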